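Swapping an ether substituent on a sulfonamide aryl ring

A few compounds are considered here, and "the series" means these few. Any claim that something is new, unique, unknown or untested is made for them only; others in the source may bear on it.

Of the compounds shown here, two sharing one core have been measured in an assay for binding affinity to Apoptosis regulator Bcl-2 (Homo sapiens), read by fluorescence polarization, with a stated time of 2 h; a lower number here means a stronger inhibitor, a higher number a weaker inhibitor. Compound 1 `Cc1c(C(=O)NCCCN2CCN(C)CC2)c(-c2cccc(N3CCN(c4ccc(NS(=O)(=O)c5cccc(S(=O)(=O)C6CC6)c5)cc4)CC3)c2)c(-c2ccc(Cl)cc2)n1C` gives 218 nM. Compound 2 `Cc1c(C(=O)NCCCN2CCN(C)CC2)c(-c2cccc(N3CCN(c4ccc(NS(=O)(=O)c5cccc(OC(F)(F)F)c5)cc4)CC3)c2)c(-c2ccc(Cl)cc2)n1C` gives 197 nM; the two numbers sit within the scatter of each other, as the step of a 1.1-fold lower number from compound 1 to compound 2 (0.04 log units; within the scatter) shows, so neither stands apart from the other. Compound 3 `CCOc1cccc(S(=O)(=O)Nc2ccc(N3CCN(c4cccc(-c5c(C(=O)NCCCN6CCN(C)CC6)c(C)n(C)c5-c5ccc(Cl)cc5)c4)CC3)cc2)c1` differs from compound 2 in a single place: ethyl in place of trifluoromethyl on an oxygen on an aromatic ring. Going by the values given here, no measured step bears directly on this exchange; the only measured step, a 1.1-fold lower number from compound 1 to compound 2 (0.04 log units; within the scatter), concerns a different substituent at that same place and was itself small. Among the compounds with values here, with no precedent pointing either way, compound 3 is expected to stay close to compound 2, giving an estimated step of a 1.3-fold higher number from compound 2 to compound 3 (0.12 log units; within the scatter) in this assay. Compound 3 is therefore estimated at 260 nM, with a likely range from 90 nM to 750 nM.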

Compound 3, inhibition constant: 420 nM
The estimate for compound 3 lay 1.6-fold (0.21 log units) below the measured number, within the range that was stated.
By their numbers in this assay, from the lowest: compounds 2, 1 and 3 (each within the scatter of the next, the first and the last beyond it).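

Going by these compounds alone, until now, the one exchange at this place had made no difference beyond the scatter. Replacing trifluoromethyl with ethyl on an oxygen on an aromatic ring is a modest step beyond it (a 2.1-fold higher number from compound 2 to compound 3 (0.33 log units; beyond the scatter)) in this assay, so the binding number does respond to what this oxygen carries. The exchange of cyclopropylsulfonyl for ethoxy (a 1.9-fold higher number from compound 1 to compound 3 (0.28 log units; within the scatter)) stays within the scatter, so that pair cannot be told apart, and nothing available explains why the ethyl exchange shifts the number.

The compounds shown leave open how methoxy, a longer chain such as propoxy, or an amine at this place would read, and whether difluoromethoxy would fall closer to compound 2 or compound 3. As far as these compounds go, whether the step from trifluoromethyl to ethyl would hold on a different core also remains open.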